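A few compounds are considered here, and "the series" means these few. Any claim that something is new, unique, unknown or untested is made for them only; others in the source may bear on it.

Working notes on the series in an ADME assay on CHO cells (Cricetulus griseus) for inhibition, read by MTT assay; a lower number here means a stronger inhibitor, a higher number a weaker inhibitor. Compound 3 `CCNCc1cc(Cl)cc(Nc2nc3cc(F)c(F)cc3[nH]2)c1O` reads > 50000 nM, which is a limit of the assay and not a number. Compound 1 `CC(C)(C)NCc1cc(Cl)cc(Nc2nc3cc(F)c(F)cc3n2Cc2ccc(C(F)(F)F)cc2)c1O` reads > 50000 nM, and this too is a limit. Among the compounds with values here, compound 2 `CCNCc1cc(Cl)cc(Nc2nc3ccccc3n2Cc2ccc(C(F)(F)F)cc2)c1O` gives 33800 nM, the only true number so far. The readings thus gather at the limit of > 50000 nM in this assay, at which 2 of the 3 values shown sit, and compound 3 offers no number to start a step from.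

Compound 4 `CCNCc1cc(Cl)cc(Nc2nc3cc(F)c(F)cc3n2Cc2ccc(C(F)(F)F)cc2)c1O` follows from compound 3 by placing 4-(trifluoromethyl)benzyl in place of hydrogen on an aromatic nitrogen of a five-membered aromatic ring: 4-(trifluoromethyl)benzyl in place of hydrogen on an aromatic nitrogen. Within the data shown here, no pair of measured compounds isolates this change, so its size in this assay can only be judged indirectly. Compound 1 and compound 2 carry the same group. Compound 2, the closest measured compound with it, reads 33800 nM, which points to a modest move towards lower numbers. Compound 1 goes against that reading, since it stays at its limit with the group in place. A small move is therefore expected, and one lost in the scatter would be no surprise. The expected change is an at least 1.3-fold lower number from compound 3 to compound 4 (0.11 log units; that floor lies within the scatter). For compound 4 the estimated value is 38000 nM, with an expected range of 17000 nM to 70000 nM.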

Compound 4, half-maximal inhibitory concentration in the CHO assay: > 50000 nM
Compound 4: no number, only a limit; the forecaster's own chance of this, stated with the estimate: 40%; middle value at least 1.3-fold (0.11 log units) from the limit.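

In the CHO assay compound 4 reads > 50000 nM, which is a limit of the assay and not a number. The steps to compound 4 from compound 3 and from compound 1 cannot be read. The compounds shown leave open whether 4-(trifluoromethyl)benzyl in place of hydrogen, or ethyl in place of tert-butyl, moves the reading in the CHO assay at all. In a physicochemical assay for solubility, read by HPLC, measured as kinetic solubility, with a stated time of 24 h, at pH 6.5 (on this read-out higher numbers stand for higher solubility and lower numbers for lower solubility), compound 3 gives 12000 nM. In the physicochemical assay compound 4 reads < 5000 nM, which is a limit of the assay and not a number.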